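The source may hold more compounds than are shown below. What is called first, only, known or untested is meant among the compounds shown, and "the series" means these compounds.

Measured compounds:
compound 1, `COc1ccc(-c2cc3ccccc3nc2/C=C/C(=O)c2c(OC)cccc2OC)cc1`: 4520 nM
compound 2, `COc1ccc(-c2cc3ccccc3nc2/C=C/C(=O)c2ccc(Br)s2)cc1`: 910 nM
compound 3, `COc1ccc(-c2cc3ccccc3nc2/C=C/C(=O)c2ccsc2)cc1`: 6010 nM

These three compounds share one core and differ only in the aromatic group attached to the carbonyl carbon. In a functional assay on MCF7 cells (Homo sapiens) for antiproliferative activity, read by XTT assay, with a stated time of 72 h (on this read-out lower numbers stand for stronger inhibition and higher numbers for weaker inhibition), compound 1 stands second highest of the three numbers, nearest to compound 3 and furthest from compound 2. The step of a 1.3-fold higher number from compound 1 to compound 3 (0.12 log units; within the scatter) lies within the scatter, whereas a 5.0-fold lower number from compound 1 to compound 2 (0.70 log units; beyond the scatter) lies beyond it, as does a 6.6-fold higher number from compound 2 to compound 3 (0.82 log units; beyond the scatter).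

Compound 4 `COc1ccc(-c2cc3ccccc3nc2/C=C/C(=O)c2c[nH]c3ccccc23)cc1` has not yet been measured. It differs from compound 1 in that (1H-indol-3-yl in place of 2,6-dimethoxyphenyl on a carbonyl carbon). Both measured steps from compound 1 exchange the same group at the same carbonyl carbon for another aromatic ring, so they bear directly on this change: one gave a modest move to a lower number, the other no change beyond the scatter. For the measured compounds named here, no measured compound carries a hydrogen-bond donor at this place, so the entering group has no direct precedent. The expected step is a 1.5-fold lower number from compound 1 to compound 4 (0.18 log units; within the scatter), a move toward a lower number that need not exceed the scatter. Compound 4 is therefore estimated at 3000 nM, with a range from 800 nM to 12000 nM.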

Compound 4, half-maximal inhibitory concentration: > 10000 nM
Compound 4: a limit, no number (the forecaster's own chance of this, stated with the estimate: 5%); middle value at least 3.3-fold (0.52 log units) away from the limit.
By their numbers in this assay, from the lowest: compound 2; then compounds 1 and 3 (each within the scatter of the next). At a limit, above all of these: compound 4.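

Compound 4 stands at a limit of the assay and not at a number: (the limit of > 10000 nM in this assay, at which 1 of the 4 values shown sits). Putting 1H-indol-3-yl in place of 2,6-dimethoxyphenyl gives (an at least 2.2-fold higher number from compound 1 to compound 4 (0.34 log units; beyond the scatter)), so a new aromatic ring on this carbonyl carbon can also move the number upward beyond the scatter, which neither earlier step from compound 1 showed. The gap from the 5-bromothiophen-2-yl compound is large (an at least 10-fold higher number from compound 2 to compound 4 (1.04 log units; beyond the scatter)), whereas the floor of the remaining step lies within the scatter and does not separate the two compounds (an at least 1.6-fold higher number from compound 3 to compound 4 (0.22 log units; that floor lies within the scatter)).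

The entering group differs from 2,6-dimethoxyphenyl in both its rings and its hydrogen-bond donor, and the compounds shown cannot tell these apart. They also leave open how an unsubstituted phenyl or a pyridine ring would behave at this carbonyl carbon.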